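Bromo in place of trifluoromethyl: an expected partial reversal

The source may report more compounds than this note shows. Statements on the series, on what has been measured and on what is new or still open speak of the compounds shown alone.

In an assay on CHO cells for inhibition of 1,25-dihydroxyvitamin D(3) 24-hydroxylase, mitochondrial (Homo sapiens) (a lower number here means a stronger inhibitor, a higher number a weaker inhibitor), compound 2 `COc1ccc2c(c1)CC/C(=C\c1ccccc1C(F)(F)F)C2=O` gives 11200 nM, the second highest of three numbers. Compound 3 `CCc1ccccc1CC1CCc2cc(OC)ccc2C1=O` gives 1920 nM, and compound 1 `COc1ccc2c(c1)CC/C(=C\c1ccccc1C)C2=O` gives 480000 nM. The only single-change step among these, a 43-fold lower number from compound 1 to compound 2 (1.63 log units; beyond the scatter), came with trifluoromethyl in place of methyl on an aromatic carbon. Compound 4 `COc1ccc2c(c1)CC/C(=C\c1ccccc1Br)C2=O` differs from compound 2 by bromo in place of trifluoromethyl on an aromatic carbon. The group that entered in that large step now leaves, and bromo takes its place, so the step bears directly on the question. Because of a 43-fold lower number from compound 1 to compound 2 (1.63 log units; beyond the scatter) a rise in the number is expected in this assay, but a smaller one, since bromo is not methyl. Compound 4 is therefore expected to give 30000 nM, with a range from 7000 nM to 120000 nM. That amounts to an expected 2.7-fold higher number from compound 2 to compound 4 (0.43 log units; beyond the scatter).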

Compound 4, half-maximal inhibitory concentration: 122000 nM
Beside the measured number, compound 4's estimate is 4.1-fold (0.61 log units) below it; the whole stated range lies below it.
By their numbers in this assay, from the lowest: compound 3; then compound 2; then compound 4; then compound 1.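

At this position, on an aromatic carbon ortho to a large group, bromo in place of trifluoromethyl gives an 11-fold higher number from compound 2 to compound 4 (1.04 log units; beyond the scatter) in this assay, so most of the gain seen with trifluoromethyl is lost. Bromo in place of methyl gives only a 3.9-fold lower number from compound 1 to compound 4 (0.59 log units; beyond the scatter) and so recovers a smaller part of that gain. Trifluoromethyl therefore stands well ahead of both other groups here, and bromo sits between them.

No measurement available here explains this order. From the compounds shown here alone, whether a nitrile or an amine at this position could match trifluoromethyl remains open.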